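A few compounds are considered here, and "the series" means these few. Any claim that something is new, unique, unknown or untested is made for them only; others in the source may bear on it.

Measured in an assay on membranes from lung (Cavia porcellus) for binding affinity to cysteinyl leukotriene receptor (Homo sapiens); a higher number here means a weaker inhibitor, a lower number a stronger inhibitor:
- compound 1 `CC(CCCC(=O)O)c1cccc(OCc2ccc3ccccc3n2)c1`: 90 nM
- compound 2 `CCCC(CCC(=O)O)Cc1ccc(OCc2ccc3ccccc3n2)cc1`: 21 nM
- compound 3 `O=C(O)CCCOc1ccc(OCc2ccc3ccccc3n2)cc1`: 1200 nM

Compound 1 stands second highest of the three numbers in this assay; compound 2 sits lower, compound 3 higher, and both gaps lie beyond the scatter. Among the compounds with values here, no single-change pairs exist among the measured compounds, so no measured step guides the move to compound 4.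

Compound 4 `CC(CCCc1cccc(OCc2ccc3ccccc3n2)c1)C(=O)O` differs from compound 1 by 4-carboxypentyl in place of 4-carboxy-1-methylbutyl on an aromatic carbon, the same atoms joined differently. With the acid chain length unchanged, the expected step in this assay is small, if any, with no direction clearly favoured beyond the scatter. Compound 4 is thus estimated at 100 nM (range 30 nM to 350 nM), a step of a 1.1-fold higher number from compound 1 to compound 4 (0.05 log units; within the scatter) expected.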

Compound 4, inhibition constant: 85 nM
Beside the measured number, compound 4's estimate is 1.2-fold (0.07 log units) above it; low and high end bracket the measured number.
By their numbers in this assay, from the lowest: compound 2; then compounds 4 and 1 (each within the scatter of the next); then compound 3.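

Exchanging 4-carboxy-1-methylbutyl for 4-carboxypentyl on this aromatic carbon, meta to a large group, gives in this assay a 1.1-fold lower number from compound 1 to compound 4 (0.02 log units; within the scatter). Within the data shown here, this is the first single-change comparison, and it shows that this rearrangement of the same atoms leaves the number unchanged within the scatter. No measured data at hand bear on this outcome.

As far as these compounds go, whether an unbranched chain, a longer chain or a tetrazole in place of the carboxylic acid would hold the number at this position remains open.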